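From butoxy to benzyloxy: an unmeasured step

The compounds below may be only part of what the source reports. "The series", "measured", "known", "first", "only" and "open" are said of these compounds alone.

Of the compounds shown here, three have so far been read in a functional assay on RAW264.7 cells (Mus musculus) for inhibition, read by Griess assay, with stated times of 1 h and 24 h; a lower number here means a stronger inhibitor, a higher number a weaker inhibitor. Compound 1 `Cc1noc(CC2OC(=O)c3ccccc32)n1` is reported only as a limit of that assay, > 10000 nM. Compound 2 `O=C1OC(Cc2nc(-c3ccc(-c4ccccc4)cc3)no2)c2ccccc21` likewise reaches only the limit, > 10000 nM. Within the data shown here, compound 3 `CCCCOc1ccc(C(O)C2OC(=O)c3c(OC)cc(OC)cc32)cc1` is the sole compound with a number: in this assay compound 3 gives 1800 nM. That sets compound 3 apart from the rest, since the other two values sit at the limit of > 10000 nM in this assay, at which 2 of the 3 values shown sit.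

Compound 4 `COc1cc(OC)c2c(c1)C(C(O)c1ccc(OCc3ccccc3)cc1)OC2=O` has not yet been measured in this assay. It differs from compound 3 in one place: phenyl in place of propyl on a saturated chain carbon bound to an oxygen on an aromatic ring. Among the measured compounds shown here, no pair of measured compounds differs in a single place, so the size of such a step cannot be read from these data. The change keeps the oxygen on the aromatic ring and swaps a chain with no ring for a six-membered aromatic ring of carbon only. Compound 4 is expected to land close to compound 3, with a step of a 1.5-fold lower number from compound 3 to compound 4 (0.18 log units; within the scatter) that may stay within the scatter or bring a modest gain. The estimate for compound 4 in this assay is 1200 nM, within a range from 400 nM to 4000 nM.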

Compound 4, half-maximal inhibitory concentration: > 10000 nM
Compound 4 gave a limit, no number (the forecaster's own chance of this, stated with the estimate: 15%); middle value at least 8.3-fold (0.92 log units) from the limit.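

Among these compounds, the step from propyl to phenyl, on a saturated chain carbon bound to an oxygen on an aromatic ring, gives the first comparison in this assay between two compounds that differ in one place, and it reads an at least 5.5-fold higher number from compound 3 to compound 4 (0.74 log units; beyond the scatter). Going by these compounds, this position is therefore not indifferent to the group it carries: with the core unchanged, butoxy gives a measured number, whereas benzyloxy leaves only a limit, so the true size of the step remains unknown and only its lower bound can be read. Among the compounds shown here, with this result, the one measured number stands alone, and compound 4 joins the other compounds at the limit: the limit of > 10000 nM in this assay, at which 3 of the 4 values shown sit.

The compounds shown leave open whether the loss follows from the aromatic ring itself or from the larger group, since phenyl differs from propyl in both ring and heavy-atom count; cyclohexyl in the same place, or a longer chain such as hexyl, would separate the two. They also leave open whether any group at this position, such as an amine or a carboxylic acid at the end of the chain, would give a lower number than butoxy.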